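The source may report more compounds than this note shows. Statements on the series, on what has been measured and on what is new or still open speak of the compounds shown alone.

In an ADME assay on THP-1 cells (Homo sapiens) for cytotoxicity, read by MTT assay, with a stated time of 72 h (on this read-out higher numbers stand for lower toxicity in this test and lower numbers for higher toxicity in this test), compound 1 (`C=C(C(=O)OCC)C(O)c1ccc(Cl)cc1Cl`), an ethyl ester, gives 68.3 uM. The free acid compound 2 (`C=C(C(=O)O)C(O)c1ccccc1Cl`) gives > 100 uM, and this reading is a limit of the assay, not a number. Compound 2 therefore has no exact position on this scale, and any step that starts from it is uncertain.

The next compound, compound 3 (`C=C(C(=O)O)C(O)c1ccc(Cl)cc1Cl`), keeps the free acid of compound 2 and differs from it in one place: chloro in place of hydrogen on an aromatic carbon. In words, a chloro group takes the place of hydrogen on an aromatic carbon, meta to the existing chloro group and para to the group of 7 heavy atoms. Among the compounds with values here, no measured pair isolates this change. Compound 3 carries both chloro groups of compound 1, and as an ester compound 1 reads 68.3 uM, so a small fall in the number, towards higher toxicity, is expected, probably no larger than the scatter. The expected change is an at least 1.1-fold lower number from compound 2 to compound 3 (0.04 log units; that floor lies within the scatter). For compound 3, the estimated value in this assay is 90 uM, within an expected range of 45 uM to 180 uM.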

Compound 3, half-maximal toxic concentration: > 100 uM
Compound 3 gave a limit, no number (the forecaster's own chance of this, stated with the estimate: 50%); middle value at least 1.1-fold (0.04 log units) from the limit.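

Compound 2 and compound 3 both stand at a limit of the assay, not at a number, so placing a chloro group at this position, meta to a chloro group and para to a group of 7 heavy atoms, has no size that can be read: the limit of > 100 uM in this assay, at which 2 of the 3 values shown sit. What can be said is that with this chloro group in place the free acid still reads as a limit in this assay, with no number appearing. Within the data shown here, compound 3 also links the acid to the ester for the first time, since hydrogen in place of ethyl on an oxygen next to a carbonyl group gives an at least 1.4-fold higher number from compound 1 to compound 3 (0.16 log units; that floor lies within the scatter), a step whose true size may be larger but whose floor alone does not go beyond the scatter.

The compounds shown leave open how far above the limit compound 2 and compound 3 lie, and so whether the chloro group shifts the read-out at all. They also leave open whether a fluoro, methoxy or nitrile group at this position, or an amide or a longer chain in place of the ethyl ester, would give a readable number.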